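The source may report more compounds than this note shows. Statements on the series, on what has been measured and on what is new or still open speak of the compounds shown alone.

Measured compounds:

compound 1 `COc1ccc(/C=C/c2cc(/C=C/c3ccc(OC)c(OC)c3)nc(OCCCCCCBr)n2)cc1OC`: > 20000 nM
compound 2 `COc1ccc(/C=C/c2cc(/C=C/c3ccc(OC)c(OC)c3)nc(OCCCCCBr)n2)cc1OC`: > 20000 nM
compound 3 `BrCCCCCCOc1nc(/C=C/c2ccccc2)cc(/C=C/c2ccccc2)n1`: > 20000 nM

The three measured compounds were tested in a functional assay on HCT-116 cells (Homo sapiens) for cytotoxicity, read by fluorescence and resazurin assay, with a stated time of 48 h; a higher number here means a weaker inhibitor, a lower number a stronger inhibitor. For compound 1 the reading is a limit of the assay and not a number: > 20000 nM. For compound 2 the reading is again a limit, > 20000 nM. For compound 3 the reading is likewise a limit, > 20000 nM. All three values sit at the same limit: the limit of > 20000 nM in this assay, at which 3 of the 3 values shown sit.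

Compound 1 and compound 2 share a core and differ in one place, (bromo in place of bromomethyl on a saturated chain carbon, five bonds along the chain from an oxygen on an aromatic ring). From the compounds shown here alone, because both readings are limits, the step that the two limits leave unreadable from compound 1 to compound 2 cannot be read, and its size stays open.

Compound 3 carries a different core; how the core of compound 3 differs from the core of compound 1 is not broken down here. Compound 4 `BrCCCCCOc1nc(/C=C/c2ccccc2)cc(/C=C/c2ccccc2)n1` has not yet been measured in this assay. It differs from compound 3 in exactly the way compound 2 differs from compound 1, namely (bromo in place of bromomethyl on a saturated chain carbon, five bonds along the chain from an oxygen on an aromatic ring), at the same place on the chain, so the two changes are the same.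

Since the comparable step from compound 1 to compound 2 stayed within the limit, and compound 3 itself sits at that limit, compound 4 is expected to stay there too, with an expected step that the limit leaves unreadable from compound 3 to compound 4. The estimate for compound 4 in this assay is 40000 nM, with an expected range from 15000 nM to 150000 nM.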

Compound 4, half-maximal inhibitory concentration: > 20000 nM
Compound 4 ended at the assay's limit (the forecaster's own chance of this, stated with the estimate: 85%); the middle value lies beyond the limit too.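

No new step can be read from compound 3 to compound 4, since both readings in this assay are limits and not numbers, and all the values shown share one limit: the limit of > 20000 nM in this assay, at which 4 of the 4 values shown sit.

The compounds shown leave open how far each one lies beyond that limit, and so whether the chain length or the difference between the two cores changes the reading in this assay at all.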